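Working notes: from compound 3 to compound 4

The source may hold more compounds than are shown below. What is called first, only, known or untested is meant among the compounds shown, and "the series" means these compounds.

Values in a functional assay on NCI-H460 cells (Homo sapiens) for cytotoxicity, read by sulforhodamine B assay; a higher number here means a weaker inhibitor of growth, a lower number a stronger inhibitor of growth:
- compound 1 `CC1=CC[C@@H]([C@@](C)(O)CCCC(C)(C)NC=S)CC1`: > 100000 nM (a limit)
- compound 2 `CC1=CC[C@@H]([C@@](C)(O)CCCC(C)(C)NC(=S)NN)CC1`: 84000 nM
- compound 3 `COc1ccc(/C=N\NC(=S)NC(C)(C)CCC[C@](C)(O)[C@@H]2CC=C(C)CC2)cc1`: > 100000 nM (a limit)

Compound 3 gives > 100000 nM, which is a limit and not a number. It therefore stands at the limit of > 100000 nM in this assay, at which 2 of the 3 values shown sit.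

The change to compound 4 `CC1=CC[C@@H]([C@@](C)(O)CCCC(C)(C)NC(=S)N/N=C\c2cccc([N+](=O)[O-])c2)CC1` is 3-nitrophenyl in place of 4-methoxyphenyl on a carbon with a double bond to nitrogen.

Among the measured compounds shown here, two measured steps bear on it, an at least 1.1-fold lower number from compound 1 to compound 2 (0.07 log units; that floor lies within the scatter) and an at least 1.1-fold higher number from compound 2 to compound 3 (0.07 log units; that floor lies within the scatter). Both stay within the scatter, and neither exchanges one such ring group for another. No step beyond the scatter is therefore expected in this assay, in either direction.

The expected change is an at least 1.1-fold lower number from compound 3 to compound 4 (0.04 log units; that floor lies within the scatter). For compound 4 the estimated value is 90000 nM, with an expected range of 45000 nM to 150000 nM.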

Compound 4, concentration for total growth inhibition: 68600 nM
Estimate against measurement, compound 4: 1.3-fold (0.12 log units) above; low and high end bracket the measured number.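

In this assay, 3-nitrophenyl in place of 4-methoxyphenyl on a carbon with a double bond to nitrogen gives an at least 1.4-fold lower number from compound 3 to compound 4 (0.16 log units; that floor lies within the scatter). Among the compounds shown here, this is the first exchange of one ring group for another at this place, and it shows that the position tolerates such a swap with a measured value still returned. Only a floor can be read because compound 3 carries a limit and not a number: the limit of > 100000 nM in this assay, at which 2 of the 4 values shown sit.

On these data alone, the true size of the gap between these two ring groups remains open. Also open, as far as these compounds go, is how a phenyl ring carrying an amine or a carboxylic acid would read at this carbon.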